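A few compounds are considered here, and "the series" means these few. Any claim that something is new, unique, unknown or untested is made for them only; others in the source may bear on it.

Within the data shown here, compound 1 `CCOC(=O)C1CCCN(Cc2cn(C3CCCCC3OC(=O)COc3ccccc3)nn2)C1` gives 21% in an assay on nucleic acid for inhibition of Nucleic Acid, read by fluorescence, tested at 100 uM (on this read-out lower numbers stand for less inhibition and higher numbers for more inhibition at the one concentration tested (going by the name of the read-out)), standing at one end of the two numbers measured so far. Compound 2 `CCCCN(CCCC)Cc1cn(C2CCCCC2OC(=O)COc2ccccc2)nn1` gives 26% in this assay, and the step of a number 5 percentage points higher from compound 1 to compound 2 (within the scatter) stays within the scatter. Compound 3 `CCOC(=O)C1CCCN(Cc2cn(C3CCCCC3OC(=O)c3ccccc3)nn2)C1` differs from compound 1 elsewhere: phenyl in place of phenoxymethyl on a carbonyl carbon. Among the measured compounds shown here, the one measured step alters a different part of the shared core, so no measured step bears directly on this change. For compound 3 the expected step is a number 1 percentage points higher from compound 1 to compound 3 (within the scatter), nothing beyond the scatter. Compound 3 is therefore estimated at 22%, within a range from 8% to 38%.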

Compound 3, a percentage reported as inhibition, at one concentration (the size of the read-out at that concentration, not a potency): 11%
Beside the measured number, compound 3's estimate is 11 percentage points above it; the range from low to high includes it.
By their numbers in this assay, from the lowest: compounds 3, 1 and 2 (each within the scatter of the next, the first and the last beyond it).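

At this position, on a carbonyl carbon, phenyl in place of phenoxymethyl gives a number 10 percentage points lower from compound 1 to compound 3 (within the scatter) in this assay. The acyl end of the molecule can therefore lose the phenoxymethyl group without the number leaving the usual scatter. Nothing available explains this result.

Still open, as far as these compounds go, is whether a longer chain, such as 2-phenoxyethyl, or an amine on this carbonyl carbon would give a step beyond the scatter. Also open, from the compounds shown here alone, is whether the same swap gives a similar step with the dibutylamino group of compound 2.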